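The compounds below may be only part of what the source reports. "The series", "measured", "known", "first", "only" and "open" are said of these compounds alone.

Compound 1 `CCC(=O)n1nc(C)c(-c2ccc(Cl)c(Cl)c2)c1N`: in an assay on Sf9 cells for inhibition of inhibitor of nuclear factor kappa-B kinase subunit epsilon (Homo sapiens), read by ADP-Glo, with a stated time of 60 min (a higher number here means a weaker inhibitor, a lower number a stronger inhibitor), compound 1 gives > 100000 nM, a limit of the assay.
Compound 2 `Cc1nn(C(=O)C2CC2)c(N)c1-c1ccc(Cl)c(Cl)c1`: in this assay compound 2 gives > 100000 nM, also a limit.
Compound 3 `Cc1nn(C(=O)c2ccncc2)c(N)c1-c1ccc(Cl)c(Cl)c1`: in this assay compound 3 gives > 100000 nM, also a limit.

Compound 2 therefore stands at the limit (the limit of > 100000 nM in this assay, at which 3 of the 3 values shown sit), with no number of its own. The three steps among the measured compounds, a step that the two limits leave unreadable from compound 1 to compound 2, a step that the two limits leave unreadable from compound 1 to compound 3 and a step that the two limits leave unreadable from compound 2 to compound 3, all vary the group on the carbonyl carbon and leave no readable size, so none of them speaks directly to a change on the dichlorophenyl part. Compound 4 `Cc1nn(C(=O)C2CC2)c(N)c1-c1ccc(Cl)cc1` differs from compound 2 by hydrogen in place of chloro on an aromatic carbon. With every neighbour sitting at the limit, compound 4 is expected to show no step beyond the scatter, a step that the limit leaves unreadable from compound 2 to compound 4, and most likely to return a limit again. Compound 4 is estimated at 150000 nM, within 50000 nM to 500000 nM.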

Compound 4, half-maximal inhibitory concentration: > 100000 nM
Compound 4 was reported as a limit; the forecaster's own chance of this, stated with the estimate: 85%; the middle value is on the limit's open side.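

Among the compounds shown here, compound 4 gives > 100000 nM in this assay, a limit, and compound 2 also has only a limit, so no step between them can be read. The compounds shown leave open what size of change removing the chloro group makes.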